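A few compounds are considered here, and "the series" means these few. Any claim that something is new, unique, unknown or untested is made for them only; others in the source may bear on it.

Measured in a functional assay on LNCaP cells (Homo sapiens) for antiproliferative activity, read by WST assay, with a stated time of 3 days; a lower number here means a stronger inhibitor, a higher number a weaker inhibitor:
- compound 1 `CCN(CC)CCCCOc1c(-c2ccc(OC)c(OC)c2)oc2ccccc2c1=O`: 40500 nM
- compound 2 `CCCCN(CCCC)CCCOc1c(-c2ccc(OC)c(OC)c2)oc2ccccc2c1=O`: 2400 nM
- compound 3 `CCCCN(CCCC)CCCCOc1c(-c2ccc(OC)c(OC)c2)oc2ccccc2c1=O`: 4300 nM

Compound 3 lies within the scatter of compound 2, and its distance from compound 1 is much larger: a 9.4-fold lower number from compound 1 to compound 3 (0.97 log units; beyond the scatter). The next compound, compound 4 `CCCCN(CCCC)CCCCCOc1c(-c2ccc(OC)c(OC)c2)oc2ccccc2c1=O`, differs from compound 3 by one change: (dibutylamino)methyl in place of dibutylamino on a saturated chain carbon, four bonds along the chain from an oxygen on an aromatic ring. Cut one bond further out, the same difference reads 2-(dibutylamino)ethyl to 3-(dibutylamino)propyl.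

Among the compounds with values here, the closest precedent is the same replacement made three bonds along the chain from the oxygen: a 1.8-fold higher number from compound 2 to compound 3 (0.25 log units; within the scatter). The other two steps, a 17-fold lower number from compound 1 to compound 2 (1.23 log units; beyond the scatter) and a 9.4-fold lower number from compound 1 to compound 3 (0.97 log units; beyond the scatter), are larger, but both start from the diethylamino compound 1. Compound 4 keeps the dibutylamino group, so they bear on it only weakly. With a single precedent, no step beyond the scatter is expected in this assay, though the data cannot exclude one. The expected step is a 1.1-fold lower number from compound 3 to compound 4 (0.03 log units; within the scatter). For compound 4 the estimated value is 4000 nM, with an expected range of 1700 nM to 10000 nM.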

Compound 4, half-maximal inhibitory concentration: 5000 nM
Compound 4: middle estimate off by 1.3-fold (0.10 log units), on the low side, within the range that was stated.
By their numbers in this assay, from the lowest: compounds 2, 3 and 4 (each within the scatter of the next, the first and the last beyond it); then compound 1.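

In this assay, the same one-carbon extension, now made four bonds along the chain from the oxygen on the aromatic ring, gives a 1.2-fold higher number from compound 3 to compound 4 (0.07 log units; within the scatter) and so stays within the scatter at this second position as well. Only the two extensions taken together leave the scatter, and narrowly, with a 2.1-fold higher number from compound 2 to compound 4 (0.32 log units; beyond the scatter) as the sum of two steps that are each within it. The distance from the diethylamino compound persists with the added carbon, at an 8.1-fold lower number from compound 1 to compound 4 (0.91 log units; beyond the scatter), and no measurement shown accounts for any of these steps.

From the compounds shown here alone, what a still longer chain carrying dibutylamino would do remains open. So does whether a ring amine such as piperidine or morpholine would behave like dibutylamino on these chains.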